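Benzyl in Place of Hydrogen on an Aromatic Oxygen

This account rests on a few compounds, and the source may have more. Where it says the series, first, only, none or still open, it means among the compounds named here.

Compound 1 `O=c1c(Cc2coc3cccc(OCC4CCCCC4)c3c2=O)coc2ccccc12`: 4510 nM
Compound 2 `O=c1c(Cc2coc3cccc(O)c3c2=O)coc2ccccc12`: 5950 nM

In a functional assay on PC-3 cells (Homo sapiens) for antiproliferative activity, read by XTT assay (on this read-out higher numbers stand for weaker inhibition and lower numbers for stronger inhibition), compound 2 gives the highest of the two numbers; its nearest neighbour is compound 1, which gives 4510 nM. Compound 3 `O=c1c(Cc2coc3cccc(OCc4ccccc4)c3c2=O)coc2ccccc12` differs from compound 2 by benzyl in place of hydrogen on an oxygen on an aromatic ring. Within the data shown here, the single measured step that bears on this change is a 1.3-fold higher number from compound 1 to compound 2 (0.12 log units; within the scatter), in which a group left the same oxygen and the number stayed within the scatter. For compound 3 no step beyond the scatter is therefore expected in this assay, a 1.2-fold lower number from compound 2 to compound 3 (0.08 log units; within the scatter). Compound 3 is estimated at 5000 nM, with a range from 2500 nM to 10000 nM.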

Compound 3, half-maximal inhibitory concentration: 4830 nM
The estimate for compound 3 lay 1.0-fold (0.02 log units) above the measured number, within the range that was stated.
By their numbers in this assay, from the lowest: compounds 1, 3 and 2 (each within the scatter of the next).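

In this assay, benzyl on the oxygen on the aromatic ring gives a 1.2-fold lower number from compound 2 to compound 3 (0.09 log units; within the scatter) and so, like cyclohexylmethyl, leaves the number within the scatter of the hydroxy compound. Phenyl in place of cyclohexyl gives a 1.1-fold higher number from compound 1 to compound 3 (0.03 log units; within the scatter) and thus adds that swapping the ring at the end of this chain, aromatic for saturated, also shows no step beyond the scatter. Nothing given here bears on why these numbers stay so close.

As far as these compounds go, whether an amine or a carboxylic acid on this oxygen, or a longer chain between it and the ring, would give a step beyond the scatter stays open.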